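A Chloro Substituent on the Hydroxyphenyl Ring

The source may hold more compounds than are shown below. What is called first, only, known or untested is meant among the compounds shown, and "the series" means these compounds.

Compound 1 `O=C(N/N=C/c1ccccc1O)c1cccc(S(=O)(=O)N2CCOCC2)c1` and compound 2 `CCN(CC)c1ccc(/C=N/NC(=O)c2cccc(S(=O)(=O)N3CCOCC3)c2)c(O)c1` share a sulfonylmorpholine-bearing benzohydrazide core joined to a hydroxyphenyl ring. In a functional assay on PC-3 cells (Homo sapiens) for antiproliferative activity, read by MTT assay, with a stated time of 72 h (a higher number here means a weaker inhibitor, a lower number a stronger inhibitor), compound 1 gives 13800 nM, and compound 2 gives 14000 nM. Of the two numbers, that of compound 1 is the smaller, but the step of a 1.0-fold higher number from compound 1 to compound 2 (0.01 log units; within the scatter) lies within the scatter, so the two compounds cannot be told apart on this assay.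

Compound 3 `O=C(N/N=C/c1cc(Cl)ccc1O)c1cccc(S(=O)(=O)N2CCOCC2)c1` differs from compound 1 by chloro in place of hydrogen on an aromatic carbon. Going by the values given here, no measured pair bears directly on a chloro group or on this position of the ring. Among the compounds with values here, the only measured step, a diethylamino in place of hydrogen elsewhere on the same ring, left the number unchanged beyond the scatter, which is the single piece of evidence available. From this compound 3 is expected to sit close to compound 1, with a step of a 1.2-fold lower number from compound 1 to compound 3 (0.06 log units; within the scatter), in neither direction beyond the scatter. Compound 3 is therefore estimated to give 12000 nM in this assay, with a range from 5000 nM to 30000 nM.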

Compound 3, half-maximal inhibitory concentration: 10500 nM
Compound 3: middle estimate off by 1.1-fold (0.06 log units), on the high side; the measured number falls inside the stated range.
By their numbers in this assay, from the lowest: compounds 3, 1 and 2 (each within the scatter of the next).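

In this assay, going by these compounds alone, going from 2-hydroxyphenyl to 5-chloro-2-hydroxyphenyl places a chloro group on the aromatic carbon para to a hydroxy group and gives a step of a 1.3-fold lower number from compound 1 to compound 3 (0.12 log units; within the scatter) and so provides the first reading at this position, where this single chlorine atom produces no change that can be told from the scatter. The diethylamino step, a 1.0-fold higher number from compound 1 to compound 2 (0.01 log units; within the scatter) for a much larger group elsewhere on the same ring, also stays within the scatter, so neither of the two substitutions measured on this ring separates from compound 1 in this assay and the numbers give no direction for either change. No independent measurement bears on the role of the chloro group in this result.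

From the compounds shown here alone, whether another group at this same carbon, such as bromo, methoxy, an amine or a carboxylic acid, would move the number beyond the scatter remains open. So does the outcome of placing chloro on the other carbons of this ring, or of replacing the hydroxy group with methoxy or an amine.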